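A few compounds are considered here, and "the series" means these few. Any claim that something is new, unique, unknown or untested is made for them only; others in the source may bear on it.

Measured so far in a physicochemical assay, read by HPLC, in phosphate buffer, with a stated time of 2 h, at pH 7.4; on this read-out lower numbers stand for a less stable compound and higher numbers for a more stable compound:
compound 1, `CCOC(=O)N1CCN(C(=O)c2nc(Nc3cc(C4CC4)[nH]n3)c3cc(Cl)ccc3n2)C[C@H]1C`: 97.7%
compound 2, `C[C@@H]1CN(C(=O)c2nc(Nc3cc(C4CC4)[nH]n3)c3cc(Cl)ccc3n2)CCN1C(=O)OCOC(=O)C(C)(C)C`: 97.7%

Compound 2 stands level with compound 1 at the digits shown; the step of no change at the digits printed from compound 1 to compound 2 (within the scatter) lies within the scatter, so the two carbamate end groups behave alike on this read-out.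

Compound 3, `COC(=O)N1CCN(C(=O)c2nc(Nc3cc(C4CC4)[nH]n3)c3cc(Cl)ccc3n2)C[C@H]1C`, is not yet measured. Its difference from compound 2 is hydrogen in place of ((tert-butyl)carbonyl)oxy on a saturated chain carbon bound to an oxygen next to a carbonyl group, which takes the acyloxy portion off the end group and leaves a methoxycarbonyl.

Going by the values given here, only the step of no change at the digits printed from compound 1 to compound 2 (within the scatter) bears on this change, and it showed no movement beyond the scatter when that same group was introduced in place of a methyl. Reversing the sense of that step and going one carbon shorter, no shift beyond the scatter is expected in this assay; the step of a number 0.2 percentage points lower from compound 2 to compound 3 (within the scatter) is estimated to be flat. Compound 3 is therefore expected to give about 97.5%, with a range from 91% to 100%.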

Compound 3, percent of the compound remaining: 100%
Compound 3: the middle estimate sits 2.5 percentage points below what was measured, within the range that was stated.
By their numbers in this assay, from the lowest: compounds 1, 2 and 3 (each within the scatter of the next).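

In this assay, hydrogen in place of ((tert-butyl)carbonyl)oxy on a saturated chain carbon bound to an oxygen next to a carbonyl group gives a number 2.3 percentage points higher from compound 2 to compound 3 (within the scatter) and thus shows that this position tolerates removal of the whole acyloxy portion without a step beyond the scatter. Hydrogen in place of methyl at the same carbon gives a number 2.3 percentage points higher from compound 1 to compound 3 (within the scatter) and extends the same reading to the smallest substituent among the three compounds, so hydrogen, methyl and ((tert-butyl)carbonyl)oxy all read alike here. No measurement is available that bears on why these end groups read alike.

On these data alone, whether the same holds for a longer chain, an amine or a carboxylic acid at this carbon remains open. Also open, as far as these compounds go, is whether compounds 1, 2 and 3 stay level in this assay at a longer stated time or at another pH.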